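Phenoxy to phenyl on two related cores

The source may report more compounds than this note shows. Statements on the series, on what has been measured and on what is new or still open speak of the compounds shown alone.

Compound 1 `CCOC(=O)Nc1cc(NC(C)C(=O)COc2ccccc2)c([N+](=O)[O-])c(N)n1` and compound 2 `CCOC(=O)Nc1cc(NC(C)C(=O)Cc2ccccc2)c([N+](=O)[O-])c(N)n1` share one core; compound 3 `CCOC(=O)Nc1cc(NC(C)C(O)COc2ccccc2)c([N+](=O)[O-])c(N)n1` and compound 4 `CCOC(=O)Nc1cc(NC(C)C(O)Cc2ccccc2)c([N+](=O)[O-])c(N)n1` share another, and the difference between the two cores is not broken down here. In a functional assay on L1210 cells (Mus musculus), with a stated time of 48 h (a lower number here means a stronger inhibitor, a higher number a weaker inhibitor), compound 1 gives 89000 nM, compound 2 gives 10000 nM and compound 3 gives 55000 nM; the values of compound 1 and compound 3 lie within the scatter of each other. The change phenyl in place of phenoxy on a saturated chain carbon bound to a carbonyl carbon gives an 8.9-fold lower number from compound 1 to compound 2 (0.95 log units; beyond the scatter). The change phenyl in place of phenoxy on a saturated chain carbon, two bonds along the chain from an oxygen on a saturated carbon is the same kind of change, here made on a saturated chain carbon, two bonds along the chain from an oxygen on a saturated carbon, rather than on a saturated chain carbon bound to a carbonyl carbon. Compound 4 remains to be measured. For the measured compounds named here, for compound 4 a step of a 6.1-fold lower number from compound 3 to compound 4 (0.79 log units; beyond the scatter) is expected in this assay, resting on the single earlier instance an 8.9-fold lower number from compound 1 to compound 2 (0.95 log units; beyond the scatter) and widened for the changed place. Compound 4 is therefore estimated at 9000 nM, within a range of 3000 nM to 27000 nM.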

Compound 4, half-maximal inhibitory concentration: 53000 nM
The estimate for compound 4 lay 5.9-fold (0.77 log units) below the measured number; the whole stated range lies below it.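

On the core of compound 3 the phenyl for phenoxy change gives a 1.0-fold lower number from compound 3 to compound 4 (0.02 log units; within the scatter), and in this assay it does not carry over from the core of compound 1: the same change on two cores in this assay, an 8.9-fold lower number (0.95 log units; beyond the scatter) from compound 1 to compound 2 and a 1.0-fold lower number (0.02 log units; within the scatter) from compound 3 to compound 4, 8.6-fold (0.93 log units) apart, beyond the scatter of two such steps. The 1-hydroxy-2-phenylethyl group in place of benzylcarbonyl gives a 5.3-fold higher number from compound 2 to compound 4 (0.72 log units; beyond the scatter), so the lower number of the phenyl compound on the first core does not hold on the second. With one pair on each core, this shows that the change depends on the core here, but neither why it does nor how it would behave on a third core.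

The compounds shown leave open whether a longer chain between the phenyl and the carbon bearing the carbonyl or hydroxyl would also separate the two cores. An amine or a carboxylic acid in place of the phenyl is likewise untested in this comparison.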